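The source may hold more compounds than are shown below. What is called first, only, known or untested is meant among the compounds shown, and "the series" means these compounds.

The shared core of compound 1 `CC(C)c1ccc(NCN2C(=O)c3ccccc3C2=O)cc1` carries an isopropyl group on its aromatic ring, yet in an assay on isolated protein for inhibition of ribosomal protein S6 kinase alpha-2 (Homo sapiens), read by fluorescence, with a stated time of 20 min (a lower number here means a stronger inhibitor, a higher number a weaker inhibitor), compound 1 has no numerical result: the entry for compound 1 reads "not determined" (no result reported). Compound 2 `COc1ccc(NCN2C(=O)c3ccccc3C2=O)cc1` carries a methoxy group instead, and in this assay compound 2 gives 470 nM. Going by the values given here, that is the only number available, so compound 2 stands alone as the single measured reference point, with nothing to rank it against. Compound 3 `COc1ccc(N(C)CN2C(=O)c3ccccc3C2=O)cc1` differs from compound 2 in one place: methyl in place of hydrogen on a nitrogen on an aromatic ring. Among the compounds with values here, no measured pair shows what such a change does here, so any expectation rests on the value of compound 2, 470 nM, alone. A step from compound 2 to compound 3 of a 1.5-fold higher number from compound 2 to compound 3 (0.17 log units; within the scatter) is expected, small enough to sit near the usual scatter, leaning toward a weaker inhibitor. Compound 3 is therefore estimated at 700 nM, within a range from 250 nM to 2500 nM.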

Compound 3, half-maximal inhibitory concentration: 3500 nM
Compound 3: the middle estimate sits 5.0-fold (0.70 log units) below what was measured, and the stated range ends below it.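

Placing methyl in place of hydrogen on this nitrogen on an aromatic ring is not a neutral swap in this assay: the change gives a 7.4-fold higher number from compound 2 to compound 3 (0.87 log units; beyond the scatter), which makes compound 3 a clearly weaker inhibitor. Going by these compounds alone, this is the first measured pair here, and it shows that this position responds to the addition of a single carbon, a change that might look too small to matter. The data at hand offer no explanation for the size of this step.

Going by these compounds, it remains open how an ethyl group, a longer chain or an acetyl group on the same nitrogen would read in this assay. It is also unknown whether the methyl step would be similar with an amine or a carboxylic acid in place of the methoxy group on the aromatic ring.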